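The source may report more compounds than this note shows. Statements on the series, on what has been measured and on what is new or still open speak of the compounds shown alone.

Within the data shown here, compound 1 `Cc1ccc(SCc2ccc(C(=O)Nc3ccccc3N)cc2)cc1` is the only member of this small set with a number in hand: in a functional assay on HCT-116 cells (Homo sapiens) for antiproliferative activity, read by CCK-8 assay, with a stated time of 72 h (on this read-out lower numbers stand for stronger inhibition and higher numbers for weaker inhibition), compound 1 gives 2630 nM, so it stands alone and no ordering among measured compounds can be drawn from it. Compound 2 `CC(C)(C)c1ccc(SCc2ccc(/C=C/C(=O)Nc3ccccc3N)cc2)cc1` belongs to the same series, but in this assay compound 2 is recorded as "not determined" (no result reported), so it offers no comparison. Compound 3 `Nc1ccccc1NC(=O)c1ccc(CSc2ccc(F)cc2)cc1` differs from compound 1 in one place: fluoro in place of methyl on an aromatic carbon, with the rest of the shared core unchanged. Among the measured compounds shown here, no step between measured compounds is recorded, so the expectation for this exchange rests on the change itself and on compound 1 alone. The step from compound 1 to compound 3 is expected to be small, a 1.1-fold higher number from compound 1 to compound 3 (0.06 log units; within the scatter), and to stay within the scatter of repeated measurements rather than move clearly in either direction. Compound 3 is therefore estimated at 3000 nM in this assay, with a plausible range from 1200 nM to 8000 nM.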

Compound 3, half-maximal inhibitory concentration: 4010 nM
Estimate against measurement, compound 3: 1.3-fold (0.13 log units) below, and the stated range covers the measured number.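

In this assay, among these compounds, replacing methyl with fluoro on this aromatic carbon gives a 1.5-fold higher number from compound 1 to compound 3 (0.18 log units; within the scatter) and so provides the first measured step at this position, which compound 1 alone could not supply. Within this pair, 4-methylphenyl and 4-fluorophenyl cannot be told apart, so this one exchange, para to a large group, shows no clear shift in either direction. No measured information available here explains this result.

Still open, as far as these compounds go, is whether a different group at this position, such as an amine, a carboxylic acid or a longer chain, would move the number beyond the scatter. Among the compounds shown here, also open is whether the exchange of methyl for fluoro would read the same way on a core other than the one shared by compound 1 and compound 3.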